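Adding one methoxy to compound 3

The source may hold more compounds than are shown below. What is called first, only, known or untested is meant among the compounds shown, and "the series" means these compounds.

Compound 1 `COc1ccc(OC)c(/C=C/C(=O)/C=C(O)/C=C/c2cc(OC)ccc2OC)c1`: 14700 nM
Compound 2 `COc1ccc(C=C(C(=O)/C=C/c2cccc(OC)c2OC)C(=O)/C=C/c2cccc(OC)c2OC)cc1OC`: 280 nM
Compound 3 `COc1ccc(OC)c(/C=C/C(=O)C(=Cc2ccc(O)c(OC)c2)C(=O)/C=C/c2cc(OC)ccc2OC)c1`: 340 nM

These values come from a functional assay on CNE-2 cells (Homo sapiens) for antiproliferative activity, read by sulforhodamine B assay, with a stated time of 48 h; a lower number here means a stronger inhibitor, a higher number a weaker inhibitor. Compound 3 lies within the usual scatter of compound 2, while compound 1 has a much higher number, beyond the scatter. Compound 4 `COc1ccc(OC)c(/C=C/C(=O)C(=Cc2cc(OC)c(O)c(OC)c2)C(=O)/C=C/c2cc(OC)ccc2OC)c1` has a methoxy in place of hydrogen on an aromatic carbon of compound 3, ortho to a hydroxy group: methoxy in place of hydrogen on an aromatic carbon. This turns 4-hydroxy-3-methoxyphenyl into 4-hydroxy-3,5-dimethoxyphenyl. Going by the values given here, no measured pair isolates this change. Compound 2 and compound 3 differ in more than one place, yet their values stay within the scatter. The expected result is a 1.1-fold lower number from compound 3 to compound 4 (0.05 log units; within the scatter), with no change beyond the scatter. For compound 4 the estimated value is 300 nM, with an expected range of 120 nM to 800 nM.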

Compound 4, half-maximal inhibitory concentration: 450 nM
Beside the measured number, compound 4's estimate is 1.5-fold (0.18 log units) below it; low and high end bracket the measured number.
By their numbers in this assay, from the lowest: compounds 2, 3 and 4 (each within the scatter of the next); then compound 1.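

In this assay, placing a methoxy ortho to a hydroxy group, which turns 4-hydroxy-3-methoxyphenyl into 4-hydroxy-3,5-dimethoxyphenyl, gives a 1.3-fold higher number from compound 3 to compound 4 (0.12 log units; within the scatter). Going by these compounds alone, this is the first measured pair that isolates this single change, and it shows that this position can carry the added methoxy with no shift beyond the usual scatter. Nothing available explains this result. The compounds shown leave open how an amine or a longer chain such as propoxy would behave at this position. They also leave open what happens when the neighbouring hydroxy group is replaced.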